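Morpholin-4-yl for ethyl(isopropyl)amino on the sulfonyl sulfur

The compounds below may be only part of what the source reports. "The series", "measured", "known", "first", "only" and "open" are said of these compounds alone.

Compound 1 `CCOC(=O)[C@@H]1CCCN(S(=O)(=O)c2ccc(S(=O)(=O)N(CC)C(C)C)cc2)C1` gives 1600 nM in a functional assay on BXPC-3 cells (Homo sapiens) for inhibition, read by MTT assay, with a stated time of 7 days (a lower number here means a stronger inhibitor, a higher number a weaker inhibitor), the lowest of the two numbers in hand. Compound 2 `CCN(CC)S(=O)(=O)c1ccc(S(=O)(=O)N2CCC[C@@H](c3cc(C)no3)C2)cc1` gives 7700 nM in this assay, a higher number and a gap beyond the scatter. Compound 3 `CCOC(=O)[C@@H]1CCCN(S(=O)(=O)c2ccc(S(=O)(=O)N3CCOCC3)cc2)C1` differs from compound 1 in one place: morpholin-4-yl in place of ethyl(isopropyl)amino on a sulfonyl sulfur. Within the data shown here, no step between measured compounds of this kind is in hand, so the expected step of a 1.1-fold higher number from compound 1 to compound 3 (0.05 log units; within the scatter) is small, in no preferred direction, and likely within the scatter. Compound 3 is therefore expected at 1800 nM in this assay, with a range from 700 nM to 4500 nM.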

Compound 3, half-maximal inhibitory concentration: 23400 nM
The estimate for compound 3 lay 13-fold (1.11 log units) below the measured number; measured number above the stated range.
By their numbers in this assay, from the lowest: compound 1; then compound 2; then compound 3.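

In this assay, the group on the sulfonyl sulfur proves to be a sensitive place in the core of compound 1: morpholin-4-yl in place of ethyl(isopropyl)amino gives a 15-fold higher number from compound 1 to compound 3 (1.17 log units; beyond the scatter). The heavy-atom count stays the same, while the open chain gives way to a ring carrying one hydrogen-bond acceptor. No data in hand explain the loss.

From the compounds shown here alone, whether the ring itself or its oxygen goes with the loss remains open. Piperidin-1-yl or thiomorpholin-4-yl on this sulfur would separate the two.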